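This account rests on a few compounds, and the source may have more. Where it says the series, first, only, none or still open, it means among the compounds named here.

Measured in an ADME assay on Akata cells (Homo sapiens) for cytotoxicity, with a stated time of 7 days (a higher number here means that more compound is tolerated, a lower number that less compound is tolerated), all as limits:
Compound 1 (`CCCCCCCCOc1nc(N)nc2c1ncn2/C=C1/CC1(CO)CO`) gives > 20000 nM as a limit
Compound 2 (`CC(C)Nc1nc(N)nc2c1ncn2/C=C1/CC1(CO)CO`) gives > 24000 nM as a limit
Compound 3 (`Nc1nc(NC2CC2)c2ncn(/C=C3/CC3(CO)CO)c2n1`) gives > 20000 nM as a limit

Compound 3 thus has only a limit and no number, like the other two compounds. Compound 4 (`Nc1nc(NC2CCCC2)c2ncn(/C=C3/CC3(CO)CO)c2n1`) has cyclopentyl in place of cyclopropyl on a nitrogen on an aromatic ring in full. The closest measured change is a step that the two limits leave unreadable from compound 2 to compound 3 and gives no size to carry over. The replacements of octyloxy, a step that the two limits leave unreadable from compound 1 to compound 2 and a step that the two limits leave unreadable from compound 1 to compound 3 as well, are no more informative. No shift beyond the scatter is therefore expected, and the estimate reads a step that the limit leaves unreadable from compound 3 to compound 4 as its expected step. Compound 4 is expected to give about 25000 nM with an estimated range from 10000 nM to 60000 nM and may well end up only as a limit.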

Compound 4, half-maximal cytotoxic concentration: > 20000 nM
Compound 4: a limit, no number; the forecaster's own chance of this, stated with the estimate: 75%; the middle value is on the limit's open side.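

Compound 4, like compound 1, compound 2 and compound 3, has only a limit in this assay, so no step among these compounds can be read. The compounds shown leave open whether changing the group on the shared core alters cytotoxicity at all.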